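Capping the hydroxy group of compound 2

The source may hold more compounds than are shown below. What is called first, only, known or untested is meant among the compounds shown, and "the series" means these compounds.

In an ADME assay on HEK293 cells (Homo sapiens) for cytotoxicity, read by reporter gene assay and resazurin assay, with a stated time of 48 h (a lower number here means that less compound is tolerated, a higher number that more compound is tolerated), compound 2 (`O=C(Nc1ccc(Sc2nc3ccccc3s2)c(Cl)c1)c1cccc(Br)c1O`) gives 64000 nM and compound 3 (`O=C(Nc1ccc(Sc2nc3ccccc3s2)cc1)c1cccc(Br)c1O`) gives 71000 nM as its result. Among the compounds with values here, these are the only two exact numbers so far, and they lie within the scatter of each other, so compound 2 stands level with compound 3. Compound 1 (`COc1c(Br)cccc1C(=O)Nc1ccccc1`) returns only a limit, > 100000 nM being its entry.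

Compound 4 (`COc1c(Br)cccc1C(=O)Nc1ccc(Sc2nc3ccccc3s2)c(Cl)c1`) differs from compound 2 in one place: methyl in place of hydrogen on an oxygen on an aromatic ring, a change that reads as hydroxy to methoxy. Within the data shown here, no measured step covers this change. Among the measured compounds shown here, the one step available, a 1.1-fold higher number from compound 2 to compound 3 (0.05 log units; within the scatter) when chloro gives way to hydrogen, is small and concerns a different group, so it is only a weak guide. With no measured sign of a larger move, the expected size in this assay is a 1.1-fold higher number from compound 2 to compound 4 (0.05 log units; within the scatter) and so no expected shift beyond the scatter in either direction. For compound 4 the estimated value is 72000 nM with an expected range from 35000 nM to 100000 nM as the likely span.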

Compound 4, half-maximal cytotoxic concentration: > 100000 nM
Compound 4 gave a limit, no number; the forecaster's own chance of this, stated with the estimate: 25%; at least 1.3-fold (0.14 log units) between middle value and limit.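

Capping the hydroxy group as methoxy takes the result in this assay from an exact number to a limit, so this change can be sized only by its floor, which reads an at least 1.5-fold higher number from compound 2 to compound 4 (0.19 log units; that floor lies within the scatter) on the oxygen on the aromatic ring. With that floor inside the scatter, the data do not establish a real shift, but they do show that methyl in place of hydrogen at this position gives no sign of a lower tolerated concentration. On these data alone, how far apart compound 2 and compound 4 truly lie stays unknown because compound 4 sits at the limit of the assay: the limit of > 100000 nM in this assay, at which 2 of the 4 values shown sit.

Still open, as far as these compounds go, is how a larger group on this oxygen, such as an ethyl group or a longer chain, would read, and whether an amine in place of the hydroxy group would read like the methoxy group. Within the data shown here, also open is whether the chloro group matters once the methoxy group is present, as the only step for that exchange, a 1.1-fold higher number from compound 2 to compound 3 (0.05 log units; within the scatter), carries a hydroxy group.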